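The compounds below may be only part of what the source reports. "The series", "measured", "known", "first", "only" and "open" are said of these compounds alone.

Measured in a functional assay on CHO cells for antagonist activity at Orexin/Hypocretin receptor type 1 (Homo sapiens), read by FLIPR and calcium flux; on this read-out lower numbers stand for lower potency and higher numbers for higher potency (the scale is a negative logarithm):
compound 1 `Cc1ccc(-c2ncccn2)c(C(=O)N2CC3(CC3)C[C@H]2CNc2ccc(C(F)(F)F)cn2)n1` gives 8.4
compound 2 `Cc1ccc(-n2nccn2)c(C(=O)N2CCC3(CC3)C[C@H]2CNc2cccc(C)n2)c1` gives 8.2
compound 3 `Cc1ccc(-c2ncccn2)c(C(=O)N2CCC3(CC3)C[C@H]2CNc2ccc(Cl)cn2)c1` gives 7.6

Compound 3 stands lowest of the three numbers in this assay; compound 2 sits higher by a gap beyond the scatter, and compound 1 sits higher still, also beyond the scatter. Compound 4 `Cc1ccc(-n2nccn2)c(C(=O)N2CCC3(CC3)C[C@H]2CNc2ccc(Cl)cn2)c1` is not yet measured. It differs from compound 3 in one place: 2H-1,2,3-triazol-2-yl in place of pyrimidin-2-yl on an aromatic carbon. Among the compounds with values here, no pair of measured compounds differs by this change alone, so no measured step stands for it; compound 2 carries the entering group but also a different substituent on the other ring, so its number alone does not isolate the swap. A small upward step is expected, within or just beyond the scatter: the estimated step is a number 0.30 log units higher from compound 3 to compound 4 (within the scatter). Compound 4 is therefore expected to give about 7.9 in this assay, between 7.3 and 8.5.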

Compound 4, negative logarithm of the antagonist equilibrium constant: 7.5
Estimate against measurement, compound 4: 0.40 log units above; low and high end bracket the measured number.
By their numbers in this assay, from the lowest: compounds 4 and 3 (each within the scatter of the next); then compounds 2 and 1 (each within the scatter of the next).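

In this assay, 2H-1,2,3-triazol-2-yl in place of pyrimidin-2-yl on this aromatic carbon gives a number 0.10 log units lower from compound 3 to compound 4 (within the scatter), so with 5-chloropyridin-2-yl on the amine nitrogen the two rings read alike. With 2H-1,2,3-triazol-2-yl held, 5-chloropyridin-2-yl in place of 6-methylpyridin-2-yl on the amine nitrogen gives a number 0.70 log units lower from compound 2 to compound 4 (beyond the scatter), so that substituent does shift the number in this pair. Nothing on hand accounts for either step. The compounds shown leave open whether the ring swap reads the same with 6-methylpyridin-2-yl on the amine nitrogen, and how a phenyl ring or a primary amine on this aromatic carbon would read.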